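One Methoxy Group Fewer on the Shared Core

A few compounds are considered here, and "the series" means these few. Any claim that something is new, unique, unknown or untested is made for them only; others in the source may bear on it.

Within the data shown here, compound 2 `COc1cc(-c2cc(/C=C/C(=O)c3ccc(N)cc3)[nH]n2)cc(OC)c1OC` holds the lower of the two numbers measured so far. In a functional assay on SR cells (Homo sapiens) for inhibition, read by sulforhodamine B assay, with a stated time of 48 h (a lower number here means a stronger inhibitor of growth, a higher number a weaker inhibitor of growth), compound 2 gives 320 nM, whereas compound 1 `COc1ccc(-c2cc(/C=C/C(=O)c3ccc(N)cc3)[nH]n2)cc1` gives 790 nM, a gap beyond the usual scatter. Compound 3 `COc1ccc(-c2cc(/C=C/C(=O)c3ccc(N)cc3)[nH]n2)cc1OC` has not been measured; it differs from compound 2 by hydrogen in place of methoxy on an aromatic carbon. Among the measured compounds shown here, no measured pair matches this change, so the expectation rests on the two measured compounds alone. Because compound 1 gives 790 nM with fewer methoxy groups, compound 3 is expected to land between the two, a modest weakening step a 1.6-fold higher number from compound 2 to compound 3 (0.19 log units; within the scatter) in this assay. The estimate for compound 3 is 500 nM, within 250 nM to 1000 nM.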

Compound 3, concentration for 50% growth inhibition: 580 nM
Beside the measured number, compound 3's estimate is 1.2-fold (0.06 log units) below it, and the stated range covers the measured number.
By their numbers in this assay, from the lowest: compounds 2, 3 and 1 (each within the scatter of the next, the first and the last beyond it).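

In this assay, hydrogen in place of methoxy on this aromatic carbon, ortho to a methoxy group and meta to a large group, gives a 1.8-fold higher number from compound 2 to compound 3 (0.26 log units; within the scatter) and the added methoxy group gives a 1.4-fold lower number from compound 1 to compound 3 (0.13 log units; within the scatter) on the other side. Neither single change can therefore be told apart from repeated measurement, so this carbon tolerates either substituent here. Nothing available explains this tolerance. From the compounds shown here alone, whether an amine, a hydroxyl group or an ethoxy group at this carbon would shift growth inhibition beyond the scatter remains open.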